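The source may report more compounds than this note shows. Statements on the series, on what has been measured and on what is new or still open speak of the compounds shown alone.

Compound 1 `COc1ccc(C(=O)/C=C\Nc2ccc(-c3nc4cc(OC)c(OC)c(OC)c4s3)cc2C)cc1F` gives 2900 nM in a functional assay on MDA-MB-231 cells (Homo sapiens) for antiproliferative activity, read by sulforhodamine B assay, with a stated time of 48 h; on this read-out lower numbers stand for stronger inhibition and higher numbers for weaker inhibition. Compound 2 `COc1ccc(C(=O)/C=C\Nc2ccc(-c3nc4cc(OC)c(OC)c(OC)c4s3)cc2)cc1F` gives 16500 nM in this assay, and the step of a 5.7-fold higher number from compound 1 to compound 2 (0.76 log units; beyond the scatter) comes from one change, (hydrogen in place of methyl on an aromatic carbon). Compound 3 `COc1ccc2nc(-c3ccc(N/C=C\C(=O)c4cc(OC)c(OC)c(OC)c4Br)c(C)c3)sc2c1` has a different core from compound 1; how the two cores differ is not broken down here. In this assay compound 3 gives 9400 nM, which lies within the scatter of compound 2. Compound 4 `COc1ccc2nc(-c3ccc(N/C=C\C(=O)c4cc(OC)c(OC)c(OC)c4Br)cc3)sc2c1` differs from compound 3 by hydrogen in place of methyl on an aromatic carbon. This is the same kind of change as that from compound 1 to compound 2, though the surroundings differ: in compound 3 the carbon is meta to a 6-methoxy-1,3-benzothiazol-2-yl group, in compound 1 meta to a large group. Because the earlier change gave a 5.7-fold higher number from compound 1 to compound 2 (0.76 log units; beyond the scatter), compound 4 is expected to show a step of a 4.3-fold higher number from compound 3 to compound 4 (0.63 log units; beyond the scatter). Compound 4 is therefore estimated at 40000 nM, likely between 15000 nM and 110000 nM.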

Compound 4, half-maximal inhibitory concentration: 11100 nM
Compound 4: the middle estimate sits 3.6-fold (0.56 log units) above what was measured, and the stated range ends above it.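

Replacing the methyl with hydrogen gives a 1.2-fold higher number from compound 3 to compound 4 (0.07 log units; within the scatter) in this assay, so on these two cores the same change does not carry the same size of effect: the same change on two cores in this assay, a 5.7-fold higher number (0.76 log units; beyond the scatter) from compound 1 to compound 2 and a 1.2-fold higher number (0.07 log units; within the scatter) from compound 3 to compound 4, 4.8-fold (0.68 log units) apart, beyond the scatter of two such steps

This shows that a step measured on one core cannot simply be transferred to the other in this series. Among the compounds shown here, with only two pairs, it does not show which of the differences between the cores matters, why the steps differ, or what the step would be on a third core.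

Still open, as far as these compounds go, is how an ethyl group or a chlorine atom on that same aromatic carbon would compare with methyl and hydrogen on either core.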